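Working notes: fluoro replaced by methoxy, compound 4

This account rests on a few compounds, and the source may have more. Where it says the series, first, only, none or still open, it means among the compounds named here.

Measured so far:
compound 1 `COc1ccc2oc(=O)c(/C=C/C(=O)N3CCC=CC3=O)c(O)c2c1` — 7100 nM
compound 2 `O=C1C=CCCN1C(=O)/C=C/c1c(O)c2ccc(F)cc2oc1=O` — 9700 nM
compound 3 `O=C1C=CCCN1C(=O)/C=C/c1c(O)c2ccccc2oc1=O` — 6700 nM

In a functional assay on HepG2 cells (Homo sapiens) for inhibition, read by MTT assay, with a stated time of 72 h (a lower number here means a stronger inhibitor, a higher number a weaker inhibitor), the three numbers sit close together: compound 2 differs from compound 1 and from compound 3 by less than the scatter, so no order among them can be read. Compound 4 `COc1ccc2c(O)c(/C=C/C(=O)N3CCC=CC3=O)c(=O)oc2c1` is the next member, untested; it differs from compound 2 by methoxy in place of fluoro on an aromatic carbon. Going by the values given here, two measured steps bear on this. Removing the fluoro gave a 1.4-fold lower number from compound 2 to compound 3 (0.16 log units; within the scatter), and removing the methoxy gave a 1.1-fold lower number from compound 1 to compound 3 (0.03 log units; within the scatter); both within the scatter. The new methoxy sits at the position where compound 2 carries fluoro, not where compound 1 carries its methoxy, so the steps are only a loose guide. No step beyond the scatter is expected, namely a 1.3-fold lower number from compound 2 to compound 4 (0.11 log units; within the scatter). Compound 4 is estimated at 7500 nM, range 3500 nM to 16000 nM.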

Compound 4, half-maximal inhibitory concentration: 12000 nM
The estimate for compound 4 lay 1.6-fold (0.20 log units) below the measured number, and the stated range covers the measured number.
By their numbers in this assay, from the lowest: compounds 3, 1, 2 and 4 (each within the scatter of the next).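

At this position in this assay the exchange of fluoro for methoxy gives a 1.2-fold higher number from compound 2 to compound 4 (0.09 log units; within the scatter) and methoxy in place of hydrogen gives a 1.8-fold higher number from compound 3 to compound 4 (0.25 log units; within the scatter) and neither step leaves the scatter. Hydrogen, fluoro and methoxy on this one aromatic carbon therefore cannot be told apart, even with the extra heavy atom and hydrogen-bond acceptor that methoxy brings. No measurement at hand bears on the reason for these numbers.

As far as these compounds go, whether an amine or a carboxylic acid on this carbon would give a step beyond the scatter stays open. The same question stands for such groups where compound 1 carries its methoxy.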